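Chloro in Place of Trifluoromethyl on the Sulfonyl Ring

The source may hold more compounds than are shown below. What is called first, only, known or untested is meant among the compounds shown, and "the series" means these compounds.

Compound 1 `O=S(=O)(Nc1ccc(-c2nc3ccccc3o2)cc1)c1ccc(Cl)c(C(F)(F)F)c1`: > 63000 nM
Compound 2 `C=Cc1ccc(S(=O)(=O)Nc2ccc3oc(-c4ccccc4)nc3c2)cc1`: > 63000 nM
Compound 3 `COc1ccc(Cl)cc1S(=O)(=O)Nc1ccc2oc(-c3ccccc3)nc2c1`: > 63000 nM

Of the compounds shown here, three sharing a benzoxazole-linked sulfonamide core have been tested in an assay on isolated protein for inhibition of malate dehydrogenase, mitochondrial (Sus scrofa), with stated times of 45 min and 30 min; a lower number here means a stronger inhibitor, a higher number a weaker inhibitor. For compound 1 the result is only a limit of the assay, > 63000 nM. For compound 2 the result is likewise a limit, > 63000 nM. For compound 3 the result is again a limit, > 63000 nM. All three therefore sit at the limit of > 63000 nM in this assay, at which 3 of the 3 values shown sit, and nothing in these numbers sets compound 1 apart from the other two.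

For the measured compounds named here, the one measured step, a step that the two limits leave unreadable from compound 2 to compound 3, is left unreadable by the two limits, so it gives no size to lean on. Compound 4 `O=S(=O)(Nc1ccc(-c2nc3ccccc3o2)cc1)c1ccc(Cl)c(Cl)c1` differs from compound 1 in one place: chloro in place of trifluoromethyl on an aromatic carbon.

Going by the values given here, no measured step bears readably on this change, and because every value shown sits at the limit of > 63000 nM in this assay, at which 3 of the 3 values shown sit, there is no sign that any modification has moved the readout off the limit. The step from compound 1 to compound 4 is expected to be no larger than the scatter, a step that the limit leaves unreadable from compound 1 to compound 4. Compound 4 is estimated at 80000 nM, within 20000 nM to 300000 nM, with a strong chance that this assay again reports only a limit.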

Compound 4, half-maximal inhibitory concentration: > 63000 nM
Compound 4: a limit, no number; the forecaster's own chance of this, stated with the estimate: 75%; the middle value is on the limit's open side.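

In this assay compound 4 gives > 63000 nM as its result, and this is only a limit. No size can be read for the step between compound 1 and compound 4. The compounds shown leave open whether any change to the shared core or the sulfonyl ring can bring a value off the limit: the limit of > 63000 nM in this assay, at which 4 of the 4 values shown sit.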